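Swapping the benzyl group on compound 3

The compounds below may be only part of what the source reports. "The series", "measured", "known", "first", "only" and "open" are said of these compounds alone.

Measured in a functional assay on A-375 cells (Homo sapiens) for antiproliferative activity, read by MTT assay, with a stated time of 24 h; on this read-out higher numbers stand for weaker inhibition and lower numbers for stronger inhibition:
compound 1 `C=CCOc1ccc2c(=O)c(-c3cc(OC)c(OC)cc3OC)coc2c1`: 4750 nM
compound 2 `COc1cccc(C(=O)Oc2ccc3c(=O)c(-c4cc(OC)c(OC)cc4OC)coc3c2)c1`: > 10000 nM (a limit)
compound 3 `COc1cc(OC)c(-c2coc3cc(OCc4ccccc4C)ccc3c2=O)cc1OC`: 1360 nM

Compound 3 at 1360 nM holds the lower of the two exact numbers. The third value, that of compound 2, is a limit. Compound 4 `COc1cc(OC)c(-c2coc3cc(OCc4cccc(Cl)c4)ccc3c2=O)cc1OC` is next, with this change: 3-chlorophenyl in place of 2-methylphenyl on a saturated chain carbon bound to an oxygen on an aromatic ring. In words, 3-chlorophenyl stands in place of 2-methylphenyl on a saturated chain carbon bound to an oxygen on an aromatic ring.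

Among the compounds with values here, three measured steps concern the same oxygen: a 3.5-fold lower number from compound 1 to compound 3 (0.54 log units; beyond the scatter), then an at least 2.1-fold higher number from compound 1 to compound 2 (0.32 log units; beyond the scatter), and an at least 7.3-fold lower number from compound 2 to compound 3 (0.86 log units; beyond the scatter) as well. Within the data shown here, each replaces one kind of group with a quite different kind, whereas no measured step compares two substituted benzyl groups. These steps therefore give no direct size for this change, and no shift beyond the scatter is expected in this assay. The expected step is a 1.1-fold higher number from compound 3 to compound 4 (0.04 log units; within the scatter) in this estimate. For compound 4 the estimated value is 1500 nM within an expected range of 500 nM to 4500 nM overall.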

Compound 4, half-maximal inhibitory concentration: 980 nM
Beside the measured number, compound 4's estimate is 1.5-fold (0.18 log units) above it; measured number inside the range.
By their numbers in this assay, from the lowest: compounds 4 and 3 (each within the scatter of the next); then compound 1. At a limit, above all of these: compound 2.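

In this assay, within the data shown here, the first comparison of two substituted benzyl groups on this oxygen gives a 1.4-fold lower number from compound 3 to compound 4 (0.14 log units; within the scatter), so 2-methylbenzyl and 3-chlorobenzyl cannot be told apart here. The 3-chlorobenzyl group also stands clear of allyl, as 2-methylbenzyl did, with a 4.8-fold lower number from compound 1 to compound 4 (0.69 log units; beyond the scatter), so this advantage over allyl is now seen with two different substituted benzyl groups. Against the ester the step reads an at least 10-fold lower number from compound 2 to compound 4 (1.00 log units; beyond the scatter), and the value of compound 2 is a limit, not a number: the limit of > 10000 nM in this assay, at which 1 of the 4 values shown sits.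

From the compounds shown here alone, what a plain benzyl group, or a chain ending in an amine or a carboxylic acid, would give on this oxygen stays open. Also open, going by these compounds, is whether any change on the benzyl ring can move the number beyond the scatter.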